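Adding a Chloro Group to Compound 2

The source may hold more compounds than are shown below. What is called first, only, known or untested is meant among the compounds shown, and "the series" means these compounds.

Measured in a functional assay on KM12 cells (Homo sapiens) for inhibition, read by sulforhodamine B assay, with a stated time of 48 h; a lower number here means a stronger inhibitor of growth, a higher number a weaker inhibitor of growth:
- compound 1 `NC(=O)c1cc(Br)ccc1NC(=O)/C=C/c1ccccc1`: 739 nM
- compound 2 `NC(=O)c1cc(I)ccc1NC(=O)/C=C/c1ccccc1`: 499 nM

Among the compounds with values here, only two compounds have been measured so far, and they cannot be ranked. Compound 2, at 499 nM, lies within the scatter of compound 1, at 739 nM. The next compound is compound 3 `NC(=O)c1cc(I)ccc1NC(=O)/C=C/c1ccccc1Cl`, which has chloro in place of hydrogen on an aromatic carbon, turning phenyl into 2-chlorophenyl (chloro in place of hydrogen on an aromatic carbon).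

Within the data shown here, the only measured step is a 1.5-fold lower number from compound 1 to compound 2 (0.17 log units; within the scatter), an exchange of bromo for iodo that stays within the scatter. Among the measured compounds shown here, no measured compound carries a change on the phenyl group, so the data give neither a size nor a direction for this step, and no shift beyond the scatter is assumed. The expected step is a 1.1-fold lower number from compound 2 to compound 3 (0.04 log units; within the scatter), with wide uncertainty. For compound 3 the estimate is 450 nM, with an expected range of 170 nM to 1200 nM.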

Compound 3, concentration for 50% growth inhibition: 533 nM
Compound 3: middle estimate off by 1.2-fold (0.07 log units), on the low side; the range from low to high includes it.
By their numbers in this assay, from the lowest: compounds 2, 3 and 1 (each within the scatter of the next).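

Within the data shown here, the step of a 1.1-fold higher number from compound 2 to compound 3 (0.03 log units; within the scatter) in this assay is the first measured change on the phenyl group, and it gives that group a first reading. Chloro on an aromatic carbon, ortho to a large group, adds one heavy atom and turning phenyl into 2-chlorophenyl brings no shift beyond the scatter, so compound 2 and compound 3 cannot be told apart here. Nothing at hand accounts for this result.

The compounds shown leave open whether this position would respond in the same way to a group other than chloro, such as methoxy, an amine or a carboxylic acid. They also leave open whether chloro placed elsewhere on the phenyl group, or two chloro groups together, would move the number beyond the scatter.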